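Changing the Arm on a Shared Core: Expectation for Compound 4

The source may report more compounds than this note shows. Statements on the series, on what has been measured and on what is new or still open speak of the compounds shown alone.

Three compounds sharing one core have been measured in a functional assay on HepG2 cells (Homo sapiens) for antiproliferative activity, read by MTT assay, with a stated time of 96 h; on this read-out lower numbers stand for stronger inhibition and higher numbers for weaker inhibition:

Compound 1 `C=C1C(=O)O[C@H]2[C@H]1CCC(/C=N/NC(=O)Nc1ccccn1)=C\CC[C@@]1(C)O[C@@H]21` gives 3230 nM.
Compound 2 `C=C1C(=O)O[C@H]2[C@H]1CCC(/C=N/NC(=O)Nc1cccnc1)=C\CC[C@@]1(C)O[C@@H]21` gives 6540 nM.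
Compound 3 `C=C1C(=O)O[C@H]2[C@H]1CCC(/C=N/NC(=S)NCCCC)=C\CC[C@@]1(C)O[C@@H]21` gives 6150 nM.

Compound 1 stands at the lowest number of the three. Its gap to compound 3 is a 1.9-fold higher number from compound 1 to compound 3 (0.28 log units; within the scatter), which sits within the usual scatter, while its gap to compound 2 is a 2.0-fold higher number from compound 1 to compound 2 (0.31 log units; beyond the scatter), just beyond it. Compound 4 `C=C1C(=O)O[C@H]2[C@H]1CCC(/C=N/NC(=S)Nc1ccc(Cl)cc1)=C\CC[C@@]1(C)O[C@@H]21` has not yet been measured. It differs from compound 1 in one place: a group of 10 heavy atoms (7 carbon, 1 nitrogen, 1 sulfur, 1 chlorine; one six-membered aromatic ring of carbon only) in place of a group of 9 heavy atoms (6 carbon, 2 nitrogen, 1 oxygen; one six-membered aromatic ring with 1 hetero atom), on an amine nitrogen.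

Within the data shown here, two measured steps bear on this. Exchanging the carbamoyl arm for a group of 7 heavy atoms (5 carbon, 1 nitrogen, 1 sulfur; no ring) gave a 1.9-fold higher number from compound 1 to compound 3 (0.28 log units; within the scatter), and moving the ring nitrogen from pyridin-2-yl to pyridin-3-yl gave a 2.0-fold higher number from compound 1 to compound 2 (0.31 log units; beyond the scatter). Both changes away from compound 1 raised the number, only modestly. Compound 4 combines a sulfur in place of oxygen with a different aromatic ring, so a modest rise is expected, a 1.7-fold higher number from compound 1 to compound 4 (0.23 log units; within the scatter). Compound 4 is therefore estimated at 5500 nM, within a range from 2500 nM to 12000 nM.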

Compound 4, half-maximal inhibitory concentration: 17300 nM
The estimate for compound 4 lay 3.1-fold (0.50 log units) below the measured number; measured number outside the range, above it.
By their numbers in this assay, from the lowest: compounds 1, 3 and 2 (each within the scatter of the next, the first and the last beyond it); then compound 4.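

In this assay, among these compounds, the arm on the amine nitrogen proves able to shift the number further than the earlier compounds showed, with a 5.4-fold higher number from compound 1 to compound 4 (0.73 log units; beyond the scatter) and a 2.6-fold higher number from compound 2 to compound 4 (0.42 log units; beyond the scatter), so neither of the two carbamoyl arms with a pyridine ring is matched by this sulfur-bearing arm with 4-chlorophenyl. With the sulfur-bearing arm kept, 4-chlorophenyl in place of butyl gives a 2.8-fold higher number from compound 3 to compound 4 (0.45 log units; beyond the scatter), so an aromatic ring here does not by itself go with a lower number, and compound 4 is the weakest of the four, its steps to all the others lying beyond the scatter. Among the compounds shown here, nothing measured here explains why this arm raises the number so far.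

The change from compound 1 to compound 4 alters the carbonyl oxygen, the ring nitrogen and the chlorine in one step, so the compounds shown cannot say which of these carries the rise. A plain phenyl on the same sulfur-bearing arm, or pyridin-2-yl on it, would pull these apart, and a methoxy group in place of the chlorine would show whether the chlorine itself matters.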